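A few compounds are considered here, and "the series" means these few. Any claim that something is new, unique, unknown or untested is made for them only; others in the source may bear on it.

Compound 2 `OCCCCC#Cc1ccccc1C#Cc1ccc(O)cc1` gives 16100 nM in a functional assay on MDA-MB-435 cells (Homo sapiens) for cytotoxicity (on this read-out higher numbers stand for weaker inhibition of growth and lower numbers for stronger inhibition of growth), the lowest of the two numbers recorded so far. Compound 1 `OCCCCC#Cc1ccccc1C#Cc1ccccn1` gives 25100 nM in this assay. That single step, a 1.6-fold lower number from compound 1 to compound 2 (0.19 log units; within the scatter), exchanged the whole ring on the triple-bonded carbon and still stayed within the scatter. Compound 3 `OCCCCC#Cc1ccccc1C#Cc1ccc(C(F)(F)F)cc1` differs from compound 2 by trifluoromethyl in place of hydroxy on an aromatic carbon. Among the measured compounds shown here, no measured step touches this position on the six-membered aromatic ring of carbon only, so the change from compound 2 offers no ground to expect a step beyond the scatter. Compound 3 is therefore expected to show a 1.0-fold lower number from compound 2 to compound 3 (0.00 log units; within the scatter), an estimated 16000 nM in this assay, with a range from 5000 nM to 50000 nM.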

Compound 3, concentration for 50% growth inhibition: 16300 nM
Beside the measured number, compound 3's estimate is 1.0-fold (0.01 log units) below it; low and high end bracket the measured number.
By their numbers in this assay, from the lowest: compounds 2, 3 and 1 (each within the scatter of the next).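

In this assay, among the compounds shown here, the step of a 1.0-fold higher number from compound 2 to compound 3 (0.01 log units; within the scatter) is the first measured change at this position on the six-membered aromatic ring of carbon only. Trifluoromethyl, with 4 heavy atoms and 0 hydrogen-bond donors or acceptors, takes the place of hydroxy here without a step beyond the scatter. No available evidence bears on this result. From the compounds shown here alone, whether an amine or a carboxylic acid on this aromatic carbon would give a step beyond the scatter remains open.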